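A changed aryl group on the amide-type nitrogen

The source may hold more compounds than are shown below. What is called first, only, known or untested is meant among the compounds shown, and "the series" means these compounds.

In a functional assay on MDA-MB-231 cells (Homo sapiens) for cytotoxicity, read by MTT assay, with a stated time of 72 h (on this read-out higher numbers stand for weaker inhibition and lower numbers for stronger inhibition), three compounds sharing one core differ only in the aryl group on an amide-type nitrogen. Compound 1 `O=C(CN1CCN(c2nnc(Cc3ccccc3)c3ccccc23)CC1)Nc1ccc(F)c(C(F)(F)F)c1` gives 760 nM, compound 2 `COc1ccc(NC(=O)CN2CCN(c3nnc(Cc4ccccc4)c4ccccc34)CC2)cc1OC` gives 32200 nM and compound 3 `O=C(CN1CCN(c2nnc(Cc3ccccc3)c3ccccc23)CC1)Nc1cc(C(F)(F)F)ccc1Cl` gives 19500 nM. The data show a 1.7-fold lower number from compound 2 to compound 3 (0.22 log units; within the scatter), but also a 26-fold higher number from compound 1 to compound 3 (1.41 log units; beyond the scatter). Compound 3 therefore stands level with compound 2, with a far higher number than compound 1.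

Compound 4 `O=C(CN1CCN(c2nnc(Cc3ccccc3)c3ccccc23)CC1)Nc1ccc(F)c(Cl)c1` makes one change: 3-chloro-4-fluorophenyl in place of 2-chloro-5-(trifluoromethyl)phenyl on an amide-type nitrogen. Here 3-chloro-4-fluorophenyl replaces 2-chloro-5-(trifluoromethyl)phenyl on an amide-type nitrogen. Changes at this place have been large, as in a 42-fold higher number from compound 1 to compound 2 (1.63 log units; beyond the scatter). Going by these compounds, the 4-fluoro-3-(trifluoromethyl)phenyl group of compound 1 is the closest measured match to the entering group, although the entering group itself is untested. A large step toward a lower number is therefore expected, given a 26-fold higher number from compound 1 to compound 3 (1.41 log units; beyond the scatter). In this assay the expected change is a 7.8-fold lower number from compound 3 to compound 4 (0.89 log units; beyond the scatter). Compound 4 is estimated at 2500 nM, with an expected range of 600 nM to 12000 nM.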

Compound 4, half-maximal inhibitory concentration: 7360 nM
Compound 4: the middle estimate sits 2.9-fold (0.47 log units) below what was measured; the measured number falls inside the stated range.
By their numbers in this assay, from the lowest: compound 1; then compound 4; then compounds 3 and 2 (each within the scatter of the next).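

In this assay, for the compounds shown here, compound 4 gives the aryl series a middle level, standing clear of the two higher numbers (a 2.6-fold lower number from compound 3 to compound 4 (0.42 log units; beyond the scatter); a 4.4-fold lower number from compound 2 to compound 4 (0.64 log units; beyond the scatter)), where the earlier compounds showed only one low number and two higher numbers. It also isolates a single exchange on the aromatic carbon, with the rest of the aryl group kept, and this exchange alone gives a 9.7-fold higher number from compound 1 to compound 4 (0.99 log units; beyond the scatter), so the low number of compound 1 is not retained when chloro stands for trifluoromethyl. Carrying a halogen on the aryl ring is therefore not enough for a low number, as compound 3 also shows, since it holds both chloro and trifluoromethyl and still stands level with compound 2.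

Going by these compounds, whether a bromo, methyl or nitrile group at that aromatic carbon would bring the number back towards that of compound 1 remains open. Nothing shown gives a measured reason for these differences.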